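Chloro for fluoro: from compound 1 to compound 4

The compounds below may be only part of what the source reports. "The series", "measured", "known", "first", "only" and "open" are said of these compounds alone.

In a functional assay on PC-3 cells (Homo sapiens) for cytotoxicity, read by MTT assay (a lower number here means a stronger inhibitor, a higher number a weaker inhibitor), compound 1 `COc1ccc2cc([C@H](C)c3nnc(SCc4ccc(Cl)cc4)n3-c3ccc(F)cc3)ccc2c1` gives <= 400000 nM, and this entry is a limit, not a number. Among the measured compounds shown here, compound 2 `COc1cccc(CSc2nnc([C@@H](C)c3ccc4cc(OC)ccc4c3)n2-c2ccc(Cl)cc2)c1` gives 138000 nM, the only exact reading. Compound 3 `COc1ccc2cc([C@H](C)c3n[nH]c(=S)n3-c3cccc(Cl)c3)ccc2c1` has no usable result, its entry being "not determined" (no result reported). Compound 1 therefore has no exact position, and comparison with compound 2 cannot be made as a measured step.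

Compound 4 `COc1ccc2cc([C@H](C)c3nnc(SCc4ccc(Cl)cc4)n3-c3ccc(Cl)cc3)ccc2c1` departs from compound 1 at one place: chloro in place of fluoro on an aromatic carbon. This is chloro in place of fluoro on an aromatic carbon, para to a large group, or 4-fluorophenyl to 4-chlorophenyl. For the measured compounds named here, no measured pair isolates this change, so the data give no direct size for it in this assay. No shift beyond the usual scatter is expected, and no direction is favoured. The expected change is a step that the limit leaves unreadable from compound 1 to compound 4. The scale of the expectation rests on compound 2 at 138000 nM. For compound 4 the estimated value is 200000 nM, with an expected range of 70000 nM to 400000 nM.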

Compound 4, half-maximal inhibitory concentration: 5800 nM
The estimate for compound 4 lay 34-fold (1.54 log units) above the measured number; measured number outside the range, below it.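

Among the compounds shown here, compound 4 gives the first exact reading with a 4-chlorophenyl on the saturated chain carbon bound to the sulfur. In this assay, 4-chlorophenyl in place of 3-methoxyphenyl at that carbon gives a 24-fold lower number from compound 2 to compound 4 (1.38 log units; beyond the scatter), so this position can move the number well beyond the scatter. The step for chloro in place of fluoro cannot be read, since compound 1 carries only a limit: the limit of <= 400000 nM in this assay, at which 1 of the 4 values shown sits.

On these data alone, the size and even the direction of the change from 4-fluorophenyl to 4-chlorophenyl therefore stay open, and a single step cannot show which feature of the 4-chlorophenyl matters at the chain carbon. Also open, as far as these compounds go, is how an amine or a carboxylic acid on that phenyl ring, in place of the chloro, would read in this assay.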